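A few compounds are considered here, and "the series" means these few. Any claim that something is new, unique, unknown or untested is made for them only; others in the source may bear on it.

Measured so far:
- compound 1, `NC(=O)c1cn(Cc2ccccc2)c2ncnc(N)c12`: 16000 nM
- compound 2, `Cn1cc(C(=N)S)c2c(N)ncnc21`: 38000 nM
- compound 3, `C=CCn1cc(C(N)=S)c2c(N)ncnc21`: 38000 nM

These three compounds share one core and differ in the group on the ring nitrogen and in the side group on the five-membered ring. In a functional assay on L1210 cells (Mus musculus) for inhibition (a lower number here means a stronger inhibitor, a higher number a weaker inhibitor), compound 1 gives 16000 nM, compound 2 gives 38000 nM and compound 3 gives 38000 nM. Compound 2 and compound 3 stand level at the digits shown, and together they hold the highest numbers of the set; compound 1 lies furthest from compound 2, with a number that is lower by a margin beyond the usual scatter.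

Compound 4, `Cc1ccc(Cn2cc(C(=N)S)c3c(N)ncnc32)cc1`, has not yet been measured in this assay. It differs from compound 2 by 4-methylphenyl in place of hydrogen on a saturated chain carbon bound to an aromatic nitrogen. For the measured compounds named here, no measured pair shows this change alone, so its effect can only be guessed from the whole set. Since compound 1, which also carries an aromatic ring on that chain carbon, gives 16000 nM while compound 2 gives 38000 nM, a modest drop in the number is expected, though the two also differ in their side group, so the step may be small or absent. Compound 4 is therefore expected to give 20000 nM in this assay, between 7000 nM and 60000 nM, with the expected step of a 1.9-fold lower number from compound 2 to compound 4 (0.28 log units; within the scatter).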

Compound 4, half-maximal inhibitory concentration: > 10000 nM
Compound 4: a limit, no number (the forecaster's own chance of this, stated with the estimate: 10%); the middle value does not contradict the limit.
By their numbers in this assay, from the lowest: compound 1; then compounds 2 and 3 (each within the scatter of the next).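

In this assay compound 4 gives > 10000 nM, which is a limit and not a number. For the compounds shown here, no step from compound 2 to compound 4 can be read from it. The compounds shown leave open how 4-methylphenyl in place of hydrogen on a saturated chain carbon bound to an aromatic nitrogen changes the number.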